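This account rests on a few compounds, and the source may have more. Where it says the series, first, only, none or still open, it means among the compounds named here.

Working notes on the series. Compound 1 `CN(C)CCn1cnnc1-c1cc(Oc2ccc(NC(=O)N/N=C/c3c[nH]c4ccccc34)cc2F)ccn1` gives 1300 nM in a functional assay on HT-29 cells (Homo sapiens) for cytotoxicity, read by MTT assay, with a stated time of 72 h (a lower number here means a stronger inhibitor, a higher number a weaker inhibitor), and stands lowest of the three numbers measured; compound 3 `Cn1cnnc1-c1cc(Oc2ccc(NC(=O)N/N=C/c3ccccc3)cc2F)ccn1` gives 8790 nM and compound 2 `Cn1ncnc1-c1cc(Oc2ccc(NC(=O)N/N=C/c3ccccc3)cc2F)ccn1` gives 30200 nM. Within the data shown here, the one single-point step measured, a 3.4-fold lower number from compound 2 to compound 3 (0.54 log units; beyond the scatter), concerns the triazole and not the hydrazone aryl. Compound 4 `CN(C)CCn1cnnc1-c1cc(Oc2ccc(NC(=O)N/N=C/c3ccc(Cl)cc3Cl)cc2F)ccn1` differs from compound 1 by 2,4-dichlorophenyl in place of 1H-indol-3-yl on a carbon with a double bond to nitrogen. Among the measured compounds shown here, no measured step bears on this change directly; compounds 2 and 3 carry a phenyl group and both show higher numbers than compound 1, but each also differs from compound 1 at the triazole, so only their values can be noted. Compound 4 is therefore expected to show a moderately higher number, a 3.1-fold higher number from compound 1 to compound 4 (0.49 log units; beyond the scatter), with the estimate 4000 nM in a range from 1500 nM to 12000 nM.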

Compound 4, half-maximal inhibitory concentration: 390 nM
Compound 4: middle estimate off by 10-fold (1.01 log units), on the high side, outside the stated range (below it).
By their numbers in this assay, from the lowest: compound 4; then compound 1; then compound 3; then compound 2.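

Among these compounds, on the carbon with a double bond to nitrogen, 2,4-dichlorophenyl in place of 1H-indol-3-yl gives a 3.3-fold lower number from compound 1 to compound 4 (0.52 log units; beyond the scatter) in this assay, the first reading of this position with the rest of compound 1 unchanged. A hydrogen-bond donor on this group is therefore not required for a number of this size. Nothing measured here accounts for the step.

Still open, as far as these compounds go, is whether the step follows from the chlorine atoms or from the phenyl ring itself, and how a single chlorine, a methoxy group or a pyridine ring would read at this place on the core of compound 1. Also open, from the compounds shown here alone, is whether the step holds with a methyl group on the triazole, as in compound 3.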